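The compounds below may be only part of what the source reports. "The series", "measured", "known", "first", "only" and "open" are said of these compounds alone.

Compound 1 `COc1ccc(OC(C)(C)C2OCC(C/C=C\CCC(=O)O)C(c3cccnc3)O2)cc1` was tested in an assay for inhibition of prostacyclin synthase (Homo sapiens), using microsomes; a higher number here means a weaker inhibitor, a lower number a stronger inhibitor. In this assay compound 1 gives only a limit, > 100000 nM, not a number. Compound 1 thus stands at the limit of > 100000 nM in this assay, at which 1 of the 3 values shown sits. Compound 2 `CC(C)(Oc1ccc(F)cc1)C1OCC(C/C=C\CCC(=O)O)C(c2cccnc2)O1` gives 2000 nM in this assay, and compound 3 `COc1ccccc1OC(C)(C)C1OCC(C/C=C\CCC(=O)O)C(c2cccnc2)O1` gives 51000 nM. Compound 4 `CC(C)(Oc1ccccc1[N+](=O)[O-])C1OCC(C/C=C\CCC(=O)O)C(c2cccnc2)O1` is unmeasured and differs from compound 1 by 2-nitrophenyl in place of 4-methoxyphenyl on an oxygen on a saturated carbon. Within the data shown here, two measured steps bear on it: an at least 50-fold lower number from compound 1 to compound 2 (1.69 log units; beyond the scatter) shows that exchanging the substituent can lower the number greatly, whereas an at least 1.9-fold lower number from compound 1 to compound 3 (0.29 log units; that floor lies within the scatter) shows a change of its position alone gave little. The comparison a 26-fold higher number from compound 2 to compound 3 (1.41 log units; beyond the scatter) is large as well. A moderate lowering is therefore expected for compound 4, estimated at 30000 nM with a range from 6000 nM to 150000 nM. The expected step is an at least 3.3-fold lower number from compound 1 to compound 4 (0.52 log units; beyond the scatter).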

Compound 4, half-maximal inhibitory concentration: < 1000 nM
Compound 4: only a limit was reported; the forecaster's own chance of this, stated with the estimate: 35%; middle value at least 30-fold (1.47 log units) away from the limit.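

In this assay, 2-nitrophenyl on this oxygen gives an at least 100-fold lower number from compound 1 to compound 4 (2.00 log units; beyond the scatter), and nitro in place of methoxy gives an at least 51-fold lower number from compound 3 to compound 4 (1.70 log units; beyond the scatter), so a substituent on this aryl group can turn a weak compound into a much stronger one without a change of its position in the name. The result for compound 4 is a limit, and an at least 2.0-fold lower number from compound 2 to compound 4 (0.30 log units; that floor lies within the scatter) therefore does not order compound 2 and compound 4. The compounds shown leave open how far the true value of compound 4 lies past its limit, and whether 4-nitrophenyl, or an amine or nitrile in place of nitro, would give a comparable number.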